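Swapping fluorophenyl for pyrimidinyl on the saturated ring

The source may hold more compounds than are shown below. What is called first, only, known or untested is meant among the compounds shown, and "the series" means these compounds.

Measured so far:
compound 1, `COc1cc(C(F)(F)F)ccc1C(=O)NC1(c2ccccc2)CCCN(C)C1`: 4800 nM
compound 2, `COc1cc(C(F)(F)F)cc(SC)c1C(=O)NC1(c2ccc(F)cc2)CCCN(C)C1`: 26 nM

Of the compounds shown here, two have been measured in an assay on cells for inhibition of sodium- and chloride-dependent glycine transporter 1 (Homo sapiens); a lower number here means that less compound is needed, a higher number that more compound is needed for the effect. Compound 1 gives 4800 nM, while compound 2 gives 26 nM. Compound 2 therefore stands at the lower of the two numbers, and its gap to compound 1 lies well beyond the usual scatter. These two compounds differ in more than one place, so no single change can be credited for that gap.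

Compound 3 `COc1cc(C(F)(F)F)cc(SC)c1C(=O)NC1(c2ccncn2)CCCN(C)C1` differs from compound 2 in one place only: pyrimidin-4-yl in place of 4-fluorophenyl on a saturated ring carbon. Among the measured compounds shown here, no measured pair shows a change of this kind, so its effect here is unknown. The step is expected to be a moderate weakening, a 3.8-fold higher number from compound 2 to compound 3 (0.59 log units; beyond the scatter), somewhat beyond the scatter. Compound 3 is accordingly estimated to give 100 nM, with a range from 25 nM to 400 nM.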

Compound 3, half-maximal effective concentration: 1700 nM
Estimate against measurement, compound 3: 17-fold (1.23 log units) below; the measured number lies above the stated range.
By their numbers in this assay, from the lowest: compound 2; then compound 3; then compound 1.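

In this assay the saturated ring carbon two ring bonds from the ring nitrogen proves sensitive to what it carries: pyrimidin-4-yl in place of 4-fluorophenyl gives a 65-fold higher number from compound 2 to compound 3 (1.82 log units; beyond the scatter), a large step. This is the only single-place comparison shown, so it isolates the effect of one group in a way that the gap between compound 1 and compound 2 could not. The change brings in an aromatic ring with 2 hetero atoms and 2 hydrogen-bond acceptors, but no measurement shown here accounts for the step.

Going by these compounds, it remains open whether the step comes from losing the fluorine or from gaining the ring nitrogens. A pyridin-4-yl group or a plain phenyl on this carbon, with the rest of compound 2 unchanged, would help separate the two.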